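Swapping a Carbamate Cap for a Sulfonamide Cap

The compounds below may be only part of what the source reports. "The series", "measured", "known", "first", "only" and "open" are said of these compounds alone.

Going by the values given here, compound 2 `CC(C)COC(=O)N1CCC(Oc2ncnc3c2CCN3c2ccc(S(C)(=O)=O)cc2F)CC1` gives 25.1 nM in a functional assay on CHO-K1 cells for agonist activity at Glucose-dependent insulinotropic receptor (Homo sapiens), read by a luciferase reporter, with a stated time of 5 h (on this read-out higher numbers stand for an effect only at larger amounts of compound and lower numbers for an effect already at smaller amounts), the lowest of the two numbers measured so far, while compound 1 `CC(C)(C)OC(=O)N1CCC(Oc2cccc3c2CCN3c2ccc(S(C)(=O)=O)cc2)CC1` gives 158 nM, a clearly higher number. The two measured compounds differ in several places, so no single change has yet been isolated. Compound 3 `CC(C)S(=O)(=O)N1CCC(Oc2ncnc3c2CCN3c2ccc(S(C)(=O)=O)cc2F)CC1` differs from compound 2 in one place: isopropylsulfonyl in place of isobutoxycarbonyl on an amine nitrogen in a ring. The expected step of a 1.6-fold higher number from compound 2 to compound 3 (0.20 log units; within the scatter) is small, leaning toward a slightly higher number. Compound 3 is therefore estimated at 40 nM, within a range from 12 nM to 130 nM.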

Compound 3, half-maximal effective concentration: 1260 nM
Compound 3: the middle estimate sits 32-fold (1.50 log units) below what was measured, outside the stated range (above it).
By their numbers in this assay, from the lowest: compound 2; then compound 1; then compound 3.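

Going by these compounds alone, on the amine nitrogen of the six-membered ring, the cap matters far more than the earlier compounds could show: isopropylsulfonyl in place of isobutoxycarbonyl gives a 50-fold higher number from compound 2 to compound 3 (1.70 log units; beyond the scatter). Both caps have no ring, no net charge and no hydrogen-bond donors, so those counts do not separate them. Nothing measured here explains the gap. As far as these compounds go, whether the loss follows the sulfonyl link or the isopropyl group stays open. Methylsulfonyl and isopropoxycarbonyl caps on the same core would help tell these two apart.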